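Swapping a fluorophenyl for a trimethoxyphenyl on the shared core

A few compounds are considered here, and "the series" means these few. Any claim that something is new, unique, unknown or untested is made for them only; others in the source may bear on it.

Measured compounds:
- compound 1 `COc1cc(-c2cc(C(=O)Nc3nc4ccc(Cl)cc4s3)nc3cc(-c4ccccc4)nn23)cc(OC)c1OC`: 41700 nM
- compound 2 `COc1ccc2nc(NC(=O)c3cc(-c4ccc(F)cc4)n4nc(-c5ccccc5)cc4n3)sc2c1`: 26300 nM

In a functional assay on ACHN cells (Homo sapiens) for cytotoxicity, read by MTT assay, with a stated time of 48 h (a higher number here means a weaker inhibitor, a lower number a stronger inhibitor), compound 2 gives 26300 nM, the lower of the two numbers, with compound 1 at 41700 nM, a gap within the scatter. Compound 3 `COc1ccc2nc(NC(=O)c3cc(-c4cc(OC)c(OC)c(OC)c4)n4nc(-c5ccccc5)cc4n3)sc2c1` keeps the core of compound 2 and differs only here: 3,4,5-trimethoxyphenyl in place of 4-fluorophenyl on an aromatic carbon. Compound 1 also carries a 3,4,5-trimethoxyphenyl and gives 41700 nM, so no step beyond the scatter is expected from compound 2 to compound 3, as a 1.3-fold higher number from compound 2 to compound 3 (0.12 log units; within the scatter) shows. Compound 3 is expected to give 35000 nM, between 12000 nM and 90000 nM.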

Compound 3, half-maximal inhibitory concentration: 5240 nM
Compound 3: the middle estimate sits 6.7-fold (0.82 log units) above what was measured; the measured number lies below the stated range.
By their numbers in this assay, from the lowest: compound 3; then compounds 2 and 1 (each within the scatter of the next).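

In this assay, 3,4,5-trimethoxyphenyl in place of 4-fluorophenyl gives a 5.0-fold lower number from compound 2 to compound 3 (0.70 log units; beyond the scatter), so this position does respond to the change. Methoxy in place of chloro gives an 8.0-fold lower number from compound 1 to compound 3 (0.90 log units; beyond the scatter), so carrying the 3,4,5-trimethoxyphenyl does not alone fix the number, and the second site matters too. Nothing measured here explains either step. Going by these compounds, it remains open whether the first step would hold with chloro in place of methoxy. Also open, on these data alone, is how a single methoxy or an amine on that phenyl ring would compare.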